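Working notes: the isomer step to compound 4

The compounds below may be only part of what the source reports. "The series", "measured", "known", "first", "only" and "open" are said of these compounds alone.

Measured in a functional assay on FM3A cells (Mus musculus) for cytotoxicity; on this read-out lower numbers stand for an effect already at smaller amounts and higher numbers for an effect only at larger amounts of compound
compound 1 `CCOOC1(OOCC)CCCCCCCCCCC1` gives 10000 nM
compound 2 `C=C(C)COOC1(OOCC(=C)C)CCCCCCCCCCC1` gives 38000 nM
compound 3 `C=C(C)COOC1(OOC)CCCCCCCCCCC1` gives 17000 nM

Compound 3 sits with compound 1, the two within the usual scatter of each other, while compound 2 carries the highest number of the three. Next comes compound 4 `C=CCCOOC1(OOC)CCCCCCCCCCC1` with the same atoms as compound 3, joined differently. The change reads allyl in place of 1-methylethenyl on a saturated chain carbon bound to an oxygen on an unsaturated carbon and, cut one bond further out, is but-3-en-1-yl in place of 2-methylprop-2-en-1-yl.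

Among the measured compounds shown here, only one measured step bears on this, and only indirectly: a 2.2-fold lower number from compound 2 to compound 3 (0.35 log units; beyond the scatter) is modest, and there 1-methylethenyl gives way to hydrogen rather than to an isomeric group. For the measured compounds named here, no measured step shows a rearrangement of this kind. In this assay no step beyond the scatter is therefore expected, in either direction. The estimated step is a 1.1-fold lower number from compound 3 to compound 4 (0.03 log units; within the scatter) and no larger one is foreseen. For compound 4 the estimated value is 16000 nM with an expected range from 8000 nM to 34000 nM for now.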

Compound 4, half-maximal effective concentration: 6000 nM
Compound 4: the middle estimate sits 2.7-fold (0.43 log units) above what was measured, outside the stated range (below it).
By their numbers in this assay, from the lowest: compounds 4, 1 and 3 (each within the scatter of the next, the first and the last beyond it); then compound 2.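

In this assay, allyl in place of 1-methylethenyl on a saturated chain carbon bound to an oxygen on an unsaturated carbon gives a 2.8-fold lower number from compound 3 to compound 4 (0.45 log units; beyond the scatter) and so shows that this position responds to how the same atoms are joined. The earlier step, a 2.2-fold lower number from compound 2 to compound 3 (0.35 log units; beyond the scatter), showed only the replacement of 1-methylethenyl by hydrogen, whereas here both groups have the same count of heavy atoms and double bonds, and the step still lies beyond the scatter. Nothing on hand explains this difference between the isomers.

Open remains whether the lower number goes with the unbranched chain or with the place of the double bond. A saturated butyl group or a longer chain such as pent-4-en-1-yl at this position would bear on that question.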